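Mirror-image pair in the series: expectation for compound 3

The source may hold more compounds than are shown below. What is called first, only, known or untested is meant among the compounds shown, and "the series" means these compounds.

Going by the values given here, compound 1 `COc1cc([C@@H]2c3[nH]c4ccccc4c3C[C@H]3C(=O)N4[C@H](c5cc(OC)c(OCc6ccccc6)c(OC)c5)c5[nH]c6ccccc6c5C[C@H]4C(=O)N23)cc(OC)c1OCc1ccccc1` and compound 2 `COc1cc([C@H]2c3[nH]c4ccccc4c3C[C@@H]3C(=O)N4[C@@H](c5cc(OC)c(O)c(OC)c5)c5[nH]c6ccccc6c5C[C@@H]4C(=O)N23)cc(OC)c1O` are the two measured members, and no single-point step connects them. In a functional assay on PC-3 cells (Homo sapiens) for cytotoxicity, tested at 10 uM (a lower number here means a stronger effect, a higher number a weaker effect of the compound at the concentration tested), compound 1 gives 98.2%. In this assay compound 2 gives > 100%, which is a limit of the assay rather than a number (the limit of > 100% in this assay, at which 1 of the 2 values shown sits). Compound 3 `COc1cc([C@@H]2c3[nH]c4ccccc4c3C[C@H]3C(=O)N4[C@H](c5cc(OC)c(O)c(OC)c5)c5[nH]c6ccccc6c5C[C@H]4C(=O)N23)cc(OC)c1O` relates to compound 2 as follows: the two compounds have the same atoms and bonds and differ only in configuration as drawn: 4 of 4 stereo elements differ (all stereocentres are inverted: mirror images); a stereocentre at a saturated ring carbon is drawn S in compound 2 and R in compound 3; a stereocentre at a saturated ring carbon is drawn R in compound 2 and S in compound 3; a stereocentre at a saturated ring carbon is drawn S in compound 2 and R in compound 3; a stereocentre at a saturated ring carbon is drawn R in compound 2 and S in compound 3. Among the compounds with values here, with no measured step available, no step beyond the usual scatter is expected in this assay for this change. Compound 3 is therefore expected to sit near the limit, estimated at 96% within 82% to 105%, a step of a number at least 4 percentage points lower from compound 2 to compound 3 (that floor lies within the scatter).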

Compound 3, a percentage reported as activity, at one concentration (the size of the read-out at that concentration, not a potency): 80.7%
Compound 3: the middle estimate sits 15.3 percentage points above what was measured; the measured number lies below the stated range.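

In this assay the inversion of all four stereocentres gives a number at least 19.3 percentage points lower from compound 2 to compound 3 (beyond the scatter), the only readable step in the series so far, and it can be assigned to configuration alone: the fact that compounds 2 and 3 differ only in the configuration as drawn

For compound 2, > 100% is a limit of the assay and not a number, so only a floor is known for the size of the step.

The contribution of any single stereocentre stays open, since only the full mirror-image pair is shown. Also open, as far as these compounds go, is whether this sensitivity to configuration persists with an amine or a carboxylic acid in place of the hydroxy groups.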